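The source may report more compounds than this note shows. Statements on the series, on what has been measured and on what is new or still open speak of the compounds shown alone.

Two close relatives of the same core open this set. Compound 1 `CCCNc1nc(=O)c2cc([N+](=O)[O-])cc([N+](=O)[O-])c2s1` carries a propylamino group and two nitro groups; in an ADME assay on Vero cells (Chlorocebus sabaeus) for cytotoxicity, read by MTT assay, with a stated time of 72 h (on this read-out higher numbers stand for weaker inhibition and lower numbers for stronger inhibition), compound 1 stands at "not determined" (no result reported), so it gives no number to lean on. Compound 2 `CCCNc1nc(=O)c2cc(C(F)(F)F)cc([N+](=O)[O-])c2s1` replaces one nitro group with a trifluoromethyl group and keeps the propylamino group. In this assay compound 2 reaches only the limit of the measurement, > 100000 nM, which is not a number but the point beyond which the assay does not measure. Going by the values given here, that is where compound 2 stands: at the limit of > 100000 nM in this assay, at which 1 of the 2 values shown sits, and with no second number beside it there is no step to compare against.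

Compound 3 `CCN(CC)c1nc(=O)c2cc(C(F)(F)F)cc([N+](=O)[O-])c2s1` is the next variation: diethylamino in place of propylamino on an aromatic carbon. Among the compounds with values here, no pair of measured compounds shows the effect of such a change here. With compound 2 sitting at the limit, the expectation is that the step from compound 2 to compound 3 amounts to a number no higher from compound 2 to compound 3 (the limit leaves the size open), that is, none beyond the scatter. Compound 3 is therefore estimated at 100000 nM, within a range from 30000 nM to 300000 nM.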

Compound 3, half-maximal inhibitory concentration: > 100000 nM
Compound 3 was reported as a limit; the forecaster's own chance of this, stated with the estimate: 80%; the middle value sits exactly at the limit.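

Compound 2 and compound 3 both end at a limit of this assay rather than at a number, so no step can be read between them: the limit of > 100000 nM in this assay, at which 2 of the 3 values shown sit.

The compounds shown leave open where either one would fall past that limit, and whether diethylamino in place of propylamino changes the read-out at all.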